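The source may report more compounds than this note shows. Statements on the series, on what has been measured and on what is new or still open speak of the compounds shown alone.

In a functional assay (strain AB) with Danio rerio as the target, read by microscopy, with a stated time of 1 h (a higher number here means that more compound is needed for the effect, a lower number that less compound is needed), compound 1 (`CCN1CCc2c(sc(NC(=O)Nc3cccc(C)c3)c2C(N)=O)C1`) gives 13000 nM and compound 2 (`CCN1CCc2c(sc(NC(=O)Nc3ccc(Cl)cc3Cl)c2C(N)=O)C1`) gives 11500 nM. For the measured compounds named here, compound 2 therefore stands within the scatter of the only other measured compound. Compound 3 (`CCN1CCc2c(sc(NC(=O)Nc3ccc(Br)cc3)c2C(N)=O)C1`) keeps the shared core and differs from compound 2 in one group: 4-bromophenyl in place of 2,4-dichlorophenyl on an amide-type nitrogen. Going by the values given here, only one measured step bears on this change, a 1.1-fold lower number from compound 1 to compound 2 (0.05 log units; within the scatter). It also exchanged one phenyl group for another on an amide-type nitrogen, and it was small. Among the compounds with values here, this single step is thin evidence, and no measured compound carries 4-bromophenyl. Even so, no step beyond the scatter is expected in this assay. The expected step is a 1.0-fold lower number from compound 2 to compound 3 (0.02 log units; within the scatter). Compound 3 is estimated at 11000 nM, with an expected range from 4500 nM to 27000 nM.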

Compound 3, half-maximal effective concentration: 3130 nM
The estimate for compound 3 lay 3.5-fold (0.55 log units) above the measured number, outside the stated range (below it).
By their numbers in this assay, from the lowest: compound 3; then compounds 2 and 1 (each within the scatter of the next).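

In this assay, the group on the amide-type nitrogen proves able to shift the number: 4-bromophenyl in place of 2,4-dichlorophenyl gives a 3.7-fold lower number from compound 2 to compound 3 (0.57 log units; beyond the scatter) and 4-bromophenyl in place of 3-methylphenyl gives a 4.2-fold lower number from compound 1 to compound 3 (0.62 log units; beyond the scatter) in a series whose earlier exchange of phenyl groups had stayed within the scatter. This place is therefore not indifferent to which phenyl group it carries, and among the three compounds only the 4-bromophenyl group stands apart beyond the scatter. Nothing shown gives a measured reason for this difference.

The compounds leave open whether the drop follows bromine itself, which a 4-chlorophenyl or 4-fluorophenyl group at this place would test. They also leave open what a carboxylic acid or an amine on that phenyl ring would do to the number.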